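Lengthening an Ester Chain: Cytotoxicity on Lung Cells

A few compounds are considered here, and "the series" means these few. Any claim that something is new, unique, unknown or untested is made for them only; others in the source may bear on it.

Three measured compounds share one core and differ only in the length of the ester chain. Compound 1 `CCCCCCCOC(=O)CCC(=O)N1CCN(CCCOc2cc3c(Nc4ccc(F)c(Cl)c4)ncnc3cc2OC)CC1` carries the shortest chain; in a functional assay on A549 cells (Homo sapiens) for cytotoxicity, read by MTT assay, with a stated time of 24 h, tested at 60 uM (on this read-out lower numbers stand for a stronger effect and higher numbers for a weaker effect at the one concentration tested), compound 1 gives 35.7%. Compound 2 `CCCCCCCCOC(=O)CCC(=O)N1CCN(CCCOc2cc3c(Nc4ccc(F)c(Cl)c4)ncnc3cc2OC)CC1` differs from it by methyl in place of hydrogen on a saturated chain carbon, seven bonds along the chain from an oxygen next to a carbonyl group, and in this assay compound 2 gives 26%, a step of a number 9.7 percentage points lower from compound 1 to compound 2 (within the scatter). Compound 3 `CCCCCCCCCCCCCOC(=O)CCC(=O)N1CCN(CCCOc2cc3c(Nc4ccc(F)c(Cl)c4)ncnc3cc2OC)CC1` differs from compound 1 by hexyl in place of hydrogen on a saturated chain carbon, seven bonds along the chain from an oxygen next to a carbonyl group; in this assay compound 3 gives 20.6%, which is a number 15.1 percentage points lower from compound 1 to compound 3 (beyond the scatter) and a number 5.4 percentage points lower from compound 2 to compound 3 (within the scatter).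

Compound 4 `CCCCCCCCCCCCCCOC(=O)CCC(=O)N1CCN(CCCOc2cc3c(Nc4ccc(F)c(Cl)c4)ncnc3cc2OC)CC1` is not yet measured. It differs from compound 3 by methyl in place of hydrogen on a saturated chain carbon, ten or more bonds along the chain from an oxygen next to a carbonyl group. This is the same kind of change as that from compound 1 to compound 2, but the place is not the same: in compound 2 the methyl entered seven bonds along the chain from an oxygen next to a carbonyl group, in compound 4 it enters more bonds along the chain from that oxygen. A step of a number 2.6 percentage points lower from compound 3 to compound 4 (within the scatter) is expected, resting on the comparable step a number 9.7 percentage points lower from compound 1 to compound 2 (within the scatter) and on the fact that all three measured values lie close together. Compound 4 is therefore estimated at 18%, with a range from 9% to 27%.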

Compound 4, a percentage reported as activity, at one concentration (the size of the read-out at that concentration, not a potency): 84.9%
The estimate for compound 4 lay 66.9 percentage points below the measured number, outside the stated range (above it).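

Carrying the methyl change from one chain length to the next did not give the same result in this assay, since it produced a number 64.3 percentage points higher from compound 3 to compound 4 (beyond the scatter), against a step within the scatter on the shorter chain: the same change on two cores in this assay, a number 9.7 percentage points lower (within the scatter) from compound 1 to compound 2 and a number 64.3 percentage points higher (beyond the scatter) from compound 3 to compound 4, 74 percentage points apart, beyond the scatter of two such steps The hexyl change also reversed direction, now giving a number 58.9 percentage points higher from compound 2 to compound 4 (beyond the scatter), well apart from its earlier step on compound 1: the same change on two cores in this assay, a number 15.1 percentage points lower (beyond the scatter) from compound 1 to compound 3 and a number 58.9 percentage points higher (beyond the scatter) from compound 2 to compound 4, 74 percentage points apart, beyond the scatter of two such steps With heptyl in place of hydrogen giving a number 49.2 percentage points higher from compound 1 to compound 4 (beyond the scatter), the result shows that a step measured on one chain length cannot be transferred to another in this series, but it does not show why the read-out rises so sharply, nor whether the rise rests on this one chain length alone.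

The compounds shown leave open where between the chains of compound 3 and compound 4 any further change would lie, and how a longer chain would read. They also leave open whether a carboxylic acid or an amide in place of the ester would follow the same course.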